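The source may report more compounds than this note shows. Statements on the series, on what has been measured and on what is new or still open speak of the compounds shown alone.

Measured so far in a functional assay on PC-3 cells (Homo sapiens) for cytotoxicity, read by sulforhodamine B assay; on this read-out lower numbers stand for stronger inhibition of growth and higher numbers for weaker inhibition of growth:

compound 1 `COc1cccc(OC)c1OCCNCCOc1ccccc1OCc1ccccc1Cl` gives 17800 nM
compound 2 `COc1cccc(OC)c1OCCNCCOc1ccccc1OCc1cccc(C)c1` gives 32300 nM
compound 3 `COc1cccc(OC)c1OCCNCCOc1ccccc1OCc1ccc(C)cc1` gives 27500 nM

Compound 3 stands second highest of the three numbers. Its nearest neighbour is compound 2, with a 1.2-fold lower number from compound 2 to compound 3 (0.07 log units; within the scatter); its furthest is compound 1, with a 1.5-fold higher number from compound 1 to compound 3 (0.19 log units; within the scatter). Both steps sit within the scatter, so no ordering of the three can be read from these values.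

Compound 4 `COc1cccc(COc2ccccc2OCCNCCOc2c(OC)cccc2OC)c1` is not yet measured. It differs from compound 3 as follows: 3-methoxyphenyl in place of 4-methylphenyl on a saturated chain carbon bound to an oxygen on an aromatic ring. All three measured steps change the group at the same place, on a saturated chain carbon bound to an oxygen on an aromatic ring: a 1.8-fold higher number from compound 1 to compound 2 (0.26 log units; within the scatter), a 1.5-fold higher number from compound 1 to compound 3 (0.19 log units; within the scatter) and a 1.2-fold lower number from compound 2 to compound 3 (0.07 log units; within the scatter). Each of them lies within the scatter, whether the change is from 2-chlorophenyl to a methylphenyl or from 3-methylphenyl to 4-methylphenyl. Among the measured compounds shown here, no measured compound carries 3-methoxyphenyl at this place, so the series gives no direct reading for that group; what it does show is that three different groups here all land on numbers within the scatter of one another.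

Compound 4 is therefore expected to stay close to compound 3, with a 1.0-fold lower number from compound 3 to compound 4 (0.01 log units; within the scatter) and no step beyond the scatter. The estimate for compound 4 in this assay is 27000 nM, with a range from 12000 nM to 60000 nM.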

Compound 4, concentration for total growth inhibition: 15100 nM
The estimate for compound 4 lay 1.8-fold (0.25 log units) above the measured number; the measured number falls inside the stated range.
By their numbers in this assay, from the lowest: compounds 4, 1, 3 and 2 (each within the scatter of the next, the first and the last beyond it).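

Among the compounds shown here, at the saturated chain carbon bound to an oxygen on an aromatic ring, the series now has its only step beyond the scatter in this assay: a 2.1-fold lower number from compound 2 to compound 4 (0.33 log units; beyond the scatter), a modest step that reads as methoxy in place of methyl on an aromatic carbon. The other two new steps stay within the scatter, a 1.8-fold lower number from compound 3 to compound 4 (0.26 log units; within the scatter) and a 1.2-fold lower number from compound 1 to compound 4 (0.07 log units; within the scatter), so 3-methoxyphenyl is separated only from 3-methylphenyl and not from 4-methylphenyl or 2-chlorophenyl, and this place is shown to tolerate all four groups with numbers spanning little more than the scatter. Nothing at hand accounts for the step from 3-methylphenyl to 3-methoxyphenyl.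

Going by these compounds, all four compounds carry a singly substituted phenyl at this place on the same core, so it remains open whether an amine or a carboxylic acid on that ring, or a longer chain in place of the benzyl link, would move the number further than these groups do. On these data alone, it also remains open whether the modest step seen here would hold on the other side of the core, where the two methoxy groups and the secondary amine stay unchanged throughout.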